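Swapping Isopropyl for Butyl on the Shared Core

The source may hold more compounds than are shown below. What is called first, only, known or untested is meant among the compounds shown, and "the series" means these compounds.

Compound 1 `CC(C)n1cnc2c(Nc3ccccc3)nc(NCOCc3ccc(C(=O)Nc4ccccc4N)cc3)nc21` has been tested in a functional assay on HepG2 cells (Homo sapiens) for antiproliferative activity, read by CCK-8 assay, with a stated time of 72 h, tested at 8 uM (on this read-out higher numbers stand for a stronger effect at the one concentration tested and lower numbers for a weaker effect), where compound 1 gives 50.2%. Its only measured companion, compound 2 `CC(C)n1cnc2c(Nc3cccc(Cl)c3)nc(NCOCc3ccc(C(=O)Nc4ccccc4N)cc3)nc21`, gives 60.5% in this assay; the step of a number 10.3 percentage points higher from compound 1 to compound 2 (beyond the scatter), chloro in place of hydrogen on an aromatic carbon, leaves compound 1 as the lower of the two numbers shown. Compound 3 `CCCCn1cnc2c(Nc3ccccc3)nc(NCOCc3ccc(C(=O)Nc4ccccc4N)cc3)nc21` has not yet been measured. It differs from compound 1 by butyl in place of isopropyl on an aromatic nitrogen. Among the measured compounds shown here, no measured step touches this group: the single step recorded concerns a chloro on an aromatic carbon, not the group on the aromatic nitrogen, so it offers no guide. With nothing to lean on, no movement beyond the usual scatter is expected in this assay, and the step of a number 0.2 percentage points lower from compound 1 to compound 3 (within the scatter) is expected to be small. Compound 3 is therefore estimated to give 50% in this assay, within a range from 36% to 64%.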

Compound 3, a percentage reported as inhibition, at one concentration (the size of the read-out at that concentration, not a potency): 70.7%
The estimate for compound 3 lay 20.7 percentage points below the measured number, outside the stated range (above it).
By their numbers in this assay, from the lowest: compound 1; then compound 2; then compound 3.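

The group on the aromatic nitrogen proves able to move the read-out: in this assay, butyl in place of isopropyl gives a number 20.5 percentage points higher from compound 1 to compound 3 (beyond the scatter), a step beyond the usual scatter. The swap is small on paper, going from 3 to 4 heavy atoms, all carbon, and neither group carries a ring, a hydrogen-bond donor, a hydrogen-bond acceptor or a net charge. Nothing available here explains the rise.

The compounds shown leave open whether a longer chain such as hexyl would raise the number further or lower it, and how a ring such as cyclopentyl or an amine at the end of the chain would fare on this nitrogen. They also leave open whether butyl and the chloro of compound 2 would add up on one molecule.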